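From Isobutyl to Isopropyl on the Nitro-Bearing Compound

This account rests on a few compounds, and the source may have more. Where it says the series, first, only, none or still open, it means among the compounds named here.

Compound 1 `CC(=O)c1ccc(NC(=O)C(CC(C)C)N(C(=O)c2ccccc2)S(=O)(=O)c2ccc(C)cc2)cc1` gives 63.1% in a functional assay for inhibition, read by spectrophotometry, with a stated time of 20 min, tested at 3 mg/mL; a lower number here means a weaker effect, a higher number a stronger effect of the compound at the concentration tested. Compound 2 `CC(=O)c1ccc(NC(=O)C(C(C)C)N(C(=O)c2ccccc2)S(=O)(=O)c2ccc(C)cc2)cc1` gives 29.7% in this assay, and compound 3 `CC(=O)c1ccc(NC(=O)C(CC(C)C)N(C(=O)c2ccccc2)S(=O)(=O)c2ccc([N+](=O)[O-])cc2)cc1` gives 62.3%, the second highest of the three numbers, within the scatter of compound 1 and clearly above compound 2. Compound 4 `CC(=O)c1ccc(NC(=O)C(C(C)C)N(C(=O)c2ccccc2)S(=O)(=O)c2ccc([N+](=O)[O-])cc2)cc1` differs from compound 3 in one place: isopropyl in place of isobutyl on a saturated chain carbon bound to an amide-type nitrogen and a carbonyl carbon. This same change has been measured once before, as a number 33.4 percentage points lower from compound 1 to compound 2 (beyond the scatter). The other known step, a number 0.8 percentage points lower from compound 1 to compound 3 (within the scatter), shows that nitro in place of methyl hardly moved the number. For compound 4 a drop of similar size is therefore expected in this assay, namely a number 32.3 percentage points lower from compound 3 to compound 4 (beyond the scatter). Compound 4 is thus estimated to give about 30%, with a range from 15% to 45%.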

Compound 4, a percentage reported as inhibition, at one concentration (the size of the read-out at that concentration, not a potency): 29.8%
Beside the measured number, compound 4's estimate is 0.2 percentage points above it, within the range that was stated.
By their numbers in this assay, from the lowest: compounds 2 and 4 (each within the scatter of the next); then compounds 3 and 1 (each within the scatter of the next).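

In this assay, isopropyl in place of isobutyl gives a number 32.5 percentage points lower from compound 3 to compound 4 (beyond the scatter), so the drop seen with methyl on the aromatic carbon also holds with nitro there: the same change on two cores in this assay, a number 33.4 percentage points lower (beyond the scatter) from compound 1 to compound 2 and a number 32.5 percentage points lower (beyond the scatter) from compound 3 to compound 4, 0.9 percentage points apart, within the scatter of two such steps. Nitro in place of methyl gives a number 0.1 percentage points higher from compound 2 to compound 4 (within the scatter), so this swap leaves the number unmoved with isopropyl as well as with isobutyl: the same change on two cores in this assay, a number 0.8 percentage points lower (within the scatter) from compound 1 to compound 3 and a number 0.1 percentage points higher (within the scatter) from compound 2 to compound 4, 0.9 percentage points apart, within the scatter of two such steps. Across these four compounds, the two changes therefore act independently of each other.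

Still open, going by these compounds, is whether a longer chain than isobutyl on this saturated chain carbon would raise the number further or lower it. On these data alone, how an amine on the aromatic carbon now holding methyl or nitro would behave also remains unknown.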